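Propoxy to 4-fluorophenoxy in the series

The source may report more compounds than this note shows. Statements on the series, on what has been measured and on what is new or still open speak of the compounds shown alone.

Compound 1 `CCCOc1ccc([C@@H]2CC(=O)c3cc(CC=C(C)C)c(OC)cc3O2)cc1` gives 43% in a functional assay on A549 cells (Homo sapiens) for inhibition, read by sulforhodamine B assay, with a stated time of 48 h, tested at 50 uM (on this read-out higher numbers stand for more inhibition of growth at the one concentration tested and lower numbers for less inhibition of growth), and sits level with compound 2 `COc1ccc([C@@H]2C/C(=N/OCc3cn(-c4ccc(C#N)cc4)nn3)c3cc(CC=C(C)C)c(OC)cc3O2)cc1` at 42% within the scatter. Compound 3 `COc1ccc([C@@H]2C/C(=N/O)c3cc(CC=C(C)C)c(OC)cc3O2)cc1` at 66% stands beyond the scatter above compound 1.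

Compound 4 `COc1cc2c(cc1CC=C(C)C)C(=O)C[C@@H](c1ccc(Oc3ccc(F)cc3)cc1)O2` has not yet been measured in this assay and differs from compound 1 in one place: 4-fluorophenyl in place of propyl on an oxygen on an aromatic ring with 4-fluorophenyl in place of propyl on an oxygen on an aromatic ring. Among the compounds with values here, no two measured compounds differ in one place only, so the series offers no direct precedent for this swap. With compound 1 at 43% as the closest reference, no change beyond the scatter is expected. The estimated step is a number 3 percentage points higher from compound 1 to compound 4 (within the scatter) and leans only slightly upward, with the direction uncertain. Compound 4 is estimated at 46% with a range of 28% to 64% expected.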

Compound 4, percent growth inhibition at one concentration: 27%
Compound 4: middle estimate off by 19 percentage points, on the high side, outside the stated range (below it).
By their numbers in this assay, from the lowest: compound 4; then compounds 2 and 1 (each within the scatter of the next); then compound 3.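

In this assay, the oxygen on an aromatic ring gives the series its first position where a single change can be read, and 4-fluorophenyl in place of propyl there gives a number 16 percentage points lower from compound 1 to compound 4 (beyond the scatter) in inhibition of growth at the one concentration tested. The position therefore does not accept every group alike: the entering six-membered aromatic ring with its fluorine goes with a lower number than the propyl chain, although this rests on one pair only. Nothing measured here bears on the reason for this drop.

From the compounds shown here alone, whether phenyl without the fluorine, benzyl or a longer chain such as butyl on the same oxygen would stay level with compound 1 remains open. Also open, going by these compounds, is whether the same swap would give a step of similar size on a core carrying an oxime in place of the carbonyl.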